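The source may hold more compounds than are shown below. What is called first, only, known or untested is meant among the compounds shown, and "the series" means these compounds.

Measured so far in a functional assay on HCT-15 cells (Homo sapiens) for cytotoxicity, in the presence of a further agent that is not named here; on this read-out lower numbers stand for stronger inhibition and higher numbers for weaker inhibition:
Compound 1 `Cc1cccc(-c2cc(-c3ccc(Cl)o3)cc(-c3ccsc3)n2)c1`: 21700 nM
Compound 2 `Cc1ccccc1-c1cc(-c2ccc(Cl)o2)cc(-c2ccsc2)n1`: 4630 nM
Compound 3 `Clc1ccc(-c2cc(-c3ccc(Cl)o3)cc(-c3ccsc3)n2)cc1`: 5190 nM

Compound 3 sits level with compound 2, as a 1.1-fold higher number from compound 2 to compound 3 (0.05 log units; within the scatter) shows. Both stand clearly lower than compound 1, so both inhibit more strongly, with a 4.2-fold lower number from compound 1 to compound 3 (0.62 log units; beyond the scatter) and a 4.7-fold lower number from compound 1 to compound 2 (0.67 log units; beyond the scatter).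

The next compound, compound 4 `Clc1ccc(-c2cc(-c3ccoc3)cc(-c3ccsc3)n2)cc1`, keeps the 4-chlorophenyl and thiophen-3-yl groups of compound 3 and changes one other group: furan-3-yl in place of 5-chlorofuran-2-yl (furan-3-yl in place of 5-chlorofuran-2-yl on an aromatic carbon). Among the compounds with values here, no measured step touches this place, so the data give no direction for the change. Within the data shown here, the only guide to size is the swap of the phenyl groups, where the two steps from compound 1 were modest and the step between compound 2 and compound 3 stayed within the scatter. A shift of similar modest size could therefore go either way, and the best guess stays near compound 3. The expected change is a 1.2-fold higher number from compound 3 to compound 4 (0.06 log units; within the scatter). The estimated value for compound 4 is 6000 nM, with an expected range from 1800 nM to 20000 nM.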

Compound 4, half-maximal inhibitory concentration: > 100000 nM
Compound 4: no number, only a limit; the forecaster's own chance of this, stated with the estimate: 10%; middle value at least 16-fold (1.22 log units) from the limit.
By their numbers in this assay, from the lowest: compounds 2 and 3 (each within the scatter of the next); then compound 1. At a limit, above all of these: compound 4.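

In this assay compound 4 gives > 100000 nM, which is a limit of the assay and not a number. Within the data shown here, the step, an at least 19-fold higher number from compound 3 to compound 4 (1.28 log units; beyond the scatter), is larger than any step among the phenyl swaps, so the group opposite the ring nitrogen matters far more to this read-out than the earlier compounds could show, and 5-chlorofuran-2-yl cannot be exchanged for furan-3-yl without a heavy loss of inhibition. As far as these compounds go, its full size stays unknown, as the reading stops at the limit: the limit of > 100000 nM in this assay, at which 1 of the 4 values shown sits.

This one change removes the chlorine and also alters how the furan is attached, so the compounds shown cannot separate the two; plain furan-2-yl or 5-chlorofuran-3-yl would do so. They also leave open how an amine or a carboxylic acid would behave at this place.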